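A few compounds are considered here, and "the series" means these few. Any claim that something is new, unique, unknown or untested is made for them only; others in the source may bear on it.

Working notes on the series. Within the data shown here, compound 2 `CC(C(=O)N1CCN(c2cccc(Cl)c2)CC1)N1C(=O)CCC1=O` carries a chloro group on the aromatic ring and in a functional assay on the whole organism (strain Swiss) with Mus musculus as the target, with a stated time of 1 h, at a dose of 100 mg/kg (on this read-out higher numbers stand for a stronger effect at the one dose given and lower numbers for a weaker effect), compound 2 gives 50%, the highest of the three numbers measured so far. Compound 1 `CC(C(=O)N1CCN(c2ccccc2C(F)(F)F)CC1)N1C(=O)CCC1=O` carries a trifluoromethyl group instead and in this assay compound 1 gives 25%, a number beyond the scatter below compound 2. Compound 3 `CCC(C(=O)N1CCN(c2cccc(C(F)(F)F)c2)CC1)N1C(=O)CCC1=O` carries trifluoromethyl together with an ethyl rather than a methyl group, and in this assay compound 3 gives 25%, likewise beyond the scatter below compound 2.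

Compound 4 `CC(C(=O)N1CCN(c2cccc(C(F)(F)F)c2)CC1)N1C(=O)CCC1=O` is reached from compound 2 by a single change: trifluoromethyl in place of chloro on an aromatic carbon. Among the measured compounds shown here, no pair of measured compounds differs in exactly this way, so the step has no direct precedent. The two compounds that already carry trifluoromethyl, compound 1 with 25% and compound 3 with 25%, both sit at the lower level. On that basis a downward step beyond the scatter is expected, estimated as a number 20 percentage points lower from compound 2 to compound 4 (beyond the scatter). Compound 4 is accordingly expected to give about 30% in this assay, within a range from 10% to 55%.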

Compound 4, a percentage reported as activity, at one dose (the size of the read-out at that dose, not a potency): 75%
Estimate against measurement, compound 4: 45 percentage points below; measured number above the stated range.
By their numbers in this assay, from the lowest: compounds 1 and 3 (each within the scatter of the next); then compound 2; then compound 4.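

On the aromatic carbon, trifluoromethyl in place of chloro gives in this assay a number 25 percentage points higher from compound 2 to compound 4 (beyond the scatter) and so is no loss at this position, which the two earlier trifluoromethyl compounds could not show, since neither differs from compound 2 in that one place alone. The saturated chain carbon proves to matter as well: with trifluoromethyl held in place, hydrogen in place of methyl there gives a number 50 percentage points higher from compound 3 to compound 4 (beyond the scatter) and shows that this group alone does not set the level of the number. Nothing measured on hand accounts for either step.

Still open, from the compounds shown here alone, is how a methoxy group, a nitrile or an amine would compare with trifluoromethyl and chloro on the same aromatic carbon. Also open is whether a longer chain on the saturated carbon continues the drop seen with the ethyl compound, and the single dose gives no potency for any of these compounds.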